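The compounds below may be only part of what the source reports. "The series", "measured", "known", "first", "only" and "open" are said of these compounds alone.

Compound 1, `COc1cc(C)cc(-c2c(-c3ccnc(-c4ccc(N(C)C)cc4)c3)cnn2CC#N)c1`, gives only a limit in a functional assay on A498 cells (Homo sapiens) for inhibition, read by sulforhodamine B assay, with a stated time of 48 h; a lower number here means a stronger inhibitor of growth, a higher number a weaker inhibitor of growth: compound 1 is recorded as > 100000 nM, which is an assay limit rather than a number. That is the limit of > 100000 nM in this assay, at which 1 of the 3 values shown sits. Two related compounds with the same core are measured with actual values. In this assay compound 2, `COc1cc(C)cc(-c2nn(CC#N)cc2-c2ccnc(-c3ccc(N(C)C)cc3)c2)c1`, gives 818 nM. In this assay compound 3, `COc1cc(C)cc(-c2nn(CC#N)cc2-c2ccc(-c3cccc(C(C)=O)c3)nc2)c1`, gives 5140 nM. Going by the values given here, no single-point step links any two of the three measured compounds, so their values can only be set side by side: compound 2 and compound 3 both show measurable concentrations for total growth inhibition, while compound 1 shows none within the tested range.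

Compound 4, `COc1cc(C)cc(-c2c(-c3ccnc(-c4ccc(C(C)=O)cc4)c3)cnn2CC#N)c1`, differs from compound 1 in one place, (acetyl in place of dimethylamino on an aromatic carbon). Since compound 1 sits at a limit, the size of the step from compound 1 to compound 4 cannot be computed, and the expectation is that compound 4 stays near that limit, with an at least 1.2-fold lower number from compound 1 to compound 4 (0.09 log units; that floor lies within the scatter) expected to be no change beyond the scatter. Compound 4 is therefore estimated at 80000 nM, in a range from 20000 nM to 300000 nM, with a good chance that this assay again reports only a limit.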

Compound 4, concentration for total growth inhibition: > 100000 nM
Compound 4 ended at the assay's limit (the forecaster's own chance of this, stated with the estimate: 60%); at least 1.2-fold (0.09 log units) between middle value and limit.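

Compound 1 and compound 4 both stand only at a limit in this assay, so no step between them can be read: the limit of > 100000 nM in this assay, at which 2 of the 4 values shown sit.

The compounds shown leave open how far past that limit each one lies, and whether acetyl and dimethylamino differ at all on this core.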